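A Primary Amide in Place of a Sulfonyl Hydrazide

A few compounds are considered here, and "the series" means these few. Any claim that something is new, unique, unknown or untested is made for them only; others in the source may bear on it.

Three compounds on the shared core have been examined in an assay on HEK293 cells for displacement of a labelled ligand from Type-2 angiotensin II receptor (Homo sapiens), tested at 1 uM (a lower number here means a weaker effect, a higher number a stronger effect of the compound at the concentration tested), and none shows more than a marginal effect. Compound 1 `CCCCNC(=O)[C@@H](NC(=O)c1cccc(Cn2ccnc2)c1)[C@@H](C)CC` is reported in this assay as "not active" (no number reported), and compound 2 `CC[C@H](C)[C@H](NC(=O)c1cccc(Cn2ccnc2)c1)c1nn[nH]n1` likewise as "not active" (no number reported). Within the data shown here, compound 3 `CC[C@H](C)[C@H](NC(=O)c1cccc(Cn2ccnc2)c1)C(=O)NNS(=O)(=O)c1ccccc1` is the only member of the set for which a number is given: in this assay compound 3 reaches 6%, a small read-out that stands alone, as the two other entries carry no number at all.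

The step now followed goes from compound 3 to compound 4 `CC[C@H](C)[C@H](NC(=O)c1cccc(Cn2ccnc2)c1)C(N)=O`. The change is hydrogen in place of (phenylsulfonyl)amino on an amide-type nitrogen, so the carbonyl now carries a plain amino group where compound 3 carried a ((phenylsulfonyl)amino)amino chain. Among the measured compounds shown here, no measured pair in this set differs in a single place, so there is no directly comparable step to lean on. Given that compound 3 itself gives only 6%, the step in this assay is expected to be a number 1 percentage points lower from compound 3 to compound 4 (within the scatter), which lies within the usual scatter rather than pointing in either direction. Compound 4 is therefore estimated to give 5% in this assay, with a plausible range from -5% to 15%.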

Compound 4, a percentage reported as inhibition, at one concentration (the size of the read-out at that concentration, not a potency): "not active" (no number reported)
Compound 4 has no reported number here; no gap can be computed for the estimate.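

Among these compounds, compound 4 stands in this assay as "not active" (no number reported) and carries no number, so no step from compound 3 to compound 4 can be read. The compounds shown leave open whether any group on the carbonyl of the shared core gives a clear read-out in this assay at all. No measurement shown bears on this result.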